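Chloro for fluoro on the phenyl of compound 2

The source may hold more compounds than are shown below. What is called first, only, known or untested is meant among the compounds shown, and "the series" means these compounds.

Compound 1 `N#Cc1c(N2CCC(c3ccccc3)CC2)ccn(CCC2CC2)c1=O` — 316%
Compound 2 `N#Cc1c(N2CCC(c3ccccc3F)CC2)ccn(CC2CC2)c1=O` — 282%

In a functional assay on CHO cells for positive allosteric modulation of metabotropic glutamate receptor 2 (Homo sapiens), with a stated time of 30 min (on this read-out lower numbers stand for smaller maximal responses and higher numbers for larger maximal responses), compound 1 gives 316% and compound 2 gives 282%. Compound 2 stands lowest of the two numbers; its nearest neighbour, compound 1, sits higher by more than the usual scatter. The two compounds differ in more than one place, so no single step can be read between them. Compound 3 `N#Cc1c(N2CCC(c3ccccc3Cl)CC2)ccn(CC2CC2)c1=O` differs from compound 2 in one place only: chloro in place of fluoro on an aromatic carbon. No step of this kind has been measured among these compounds, so its size rests on expectation alone. In this assay a modest change is expected, in no firm direction, quite possibly none beyond the scatter. For compound 3 the expected value is 290%, with a range from 230% to 350%, which means an expected step of a number 8 percentage points higher from compound 2 to compound 3 (within the scatter).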

Compound 3, largest response reached (Emax), in percent of the reference or control that the assay uses: 259%
Estimate against measurement, compound 3: 31 percentage points above; the measured number falls inside the stated range.
By their numbers in this assay, from the lowest: compound 3; then compound 2; then compound 1.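

In this assay the change from 2-fluorophenyl to 2-chlorophenyl gives a number 23 percentage points lower from compound 2 to compound 3 (beyond the scatter) and is the first step among these compounds that can be read at a single place. It shows that the maximal response is sensitive to which halogen sits on this aromatic carbon, ortho to a large group, although the step is modest and compound 3 still reaches 259% in this read-out. For the compounds shown here, compound 1 differs from compound 2 and from compound 3 in more than one place, so no step to it can be read.

The compounds shown leave open how a methyl, a methoxy or an amine would fare on this same carbon, and whether the halogen step would hold on the core of compound 1. Nothing measured here explains the size or direction of the step.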